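Swapping methoxy for methyl on the sulfonyl-bearing ring

A few compounds are considered here, and "the series" means these few. Any claim that something is new, unique, unknown or untested is made for them only; others in the source may bear on it.

Measured compounds in an ADME assay on HEK293 cells (Homo sapiens) for cytotoxicity, read by MTT assay, with a stated time of 48 h; a lower number here means a stronger inhibitor, a higher number a weaker inhibitor:
compound 1, `COc1ccc(S(=O)(=O)N2CCC[C@@H]2C(=O)N2CCN(c3ccnc4cc(Cl)ccc34)CC2)cc1`, 57700 nM
compound 2, `O=C([C@H]1CCCN1S(=O)(=O)c1ccc2ccccc2c1)N1CCN(c2ccnc3cc(Cl)ccc23)CC1`, 24400 nM

Within the data shown here, of the two numbers measured so far, compound 1 has the higher one, so it is the weaker inhibitor of cell viability in this assay; its nearest neighbour is compound 2, reached by a 2.4-fold lower number from compound 1 to compound 2 (0.37 log units; beyond the scatter), a change at the sulfonyl sulfur.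

Compound 3, `Cc1ccc(S(=O)(=O)N2CCC[C@@H]2C(=O)N2CCN(c3ccnc4cc(Cl)ccc34)CC2)cc1`, differs from compound 1 by methyl in place of methoxy on an aromatic carbon. Among the measured compounds shown here, no measured step has this change. For the measured compounds named here, the only step known, from compound 1 to compound 2, exchanges the whole aryl group on the sulfonyl sulfur and is therefore only a loose guide; it shows that this position can shift the number, but by a modest amount. For the smaller change in compound 3 the expectation is a step of a 1.3-fold lower number from compound 1 to compound 3 (0.11 log units; within the scatter), not reliably beyond the scatter. Compound 3 is therefore estimated at 45000 nM, within 20000 nM to 110000 nM.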

Compound 3, half-maximal inhibitory concentration: 81200 nM
The estimate for compound 3 lay 1.8-fold (0.26 log units) below the measured number; the measured number falls inside the stated range.
By their numbers in this assay, from the lowest: compound 2; then compounds 1 and 3 (each within the scatter of the next).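

In this assay, methyl in place of methoxy on the ring gives a 1.4-fold higher number from compound 1 to compound 3 (0.15 log units; within the scatter) and so does not separate the two compounds, even though the oxygen of the methoxy group is gone. Exchanging the whole aryl group is a different matter: a 3.3-fold higher number from compound 2 to compound 3 (0.52 log units; beyond the scatter) is a step beyond the scatter, modest in size, and compound 2 stands apart from both compound 1 and compound 3, so of these three groups on the sulfonyl sulfur only naphthalen-2-yl gives a distinct number. Nothing measured here explains either result.

On these data alone, it remains open whether an amine or a carboxylic acid on the same ring carbon would move the number beyond the scatter. A longer chain there, such as butyl, might also behave differently from the small methoxy and methyl groups.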